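Moving the Methyl Group on the Thiourea Aryl Ring

A few compounds are considered here, and "the series" means these few. Any claim that something is new, unique, unknown or untested is made for them only; others in the source may bear on it.

Measured compounds:
compound 1, `COc1cc2c(cc1OC)C(=O)C(CC1CCN(C(=S)Nc3ccccc3)CC1)C2`, gives 100 mg/kg
compound 2, `COc1cc2c(cc1OC)C(=O)C(CC1CCN(C(=S)Nc3ccccc3C)CC1)C2`, gives 100 mg/kg

Both compounds were tested in a functional assay on the whole organism (strain Swiss albino) with Mus musculus as the target, in the maximal electroshock model, with a stated time of 0.5 h; on this read-out lower numbers stand for an effect already at smaller amounts and higher numbers for an effect only at larger amounts of compound. Compound 2 stands level with compound 1 on the numbers shown: the step of no change at the digits printed from compound 1 to compound 2 (within the scatter), brought about by a methyl in place of hydrogen on an aromatic carbon, lies within the scatter of this assay.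

Compound 3, `COc1cc2c(cc1OC)C(=O)C(CC1CCN(C(=S)Nc3cccc(C)c3)CC1)C2`, is the next member of the series. It differs from compound 2 only in where the methyl sits: 3-methylphenyl in place of 2-methylphenyl on an amide-type nitrogen. The two compounds contain the same atoms, joined differently.

For the measured compounds named here, only one measured step is available, and it concerns adding the methyl rather than shifting it. That step, no change at the digits printed from compound 1 to compound 2 (within the scatter), showed that a 2-methylphenyl in place of a phenyl made no difference the assay could resolve. Since the same group is merely relocated, no step beyond the scatter is expected in this assay, in either direction. The step from compound 2 to compound 3 is therefore estimated as no change at the digits printed from compound 2 to compound 3 (within the scatter). Compound 3 is expected to give about 100 mg/kg, with a likely range from 50 mg/kg to 200 mg/kg.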

Compound 3, minimum effective dose: 300 mg/kg
Beside the measured number, compound 3's estimate is 3.0-fold (0.48 log units) below it, outside the stated range (above it).
By their numbers in this assay, from the lowest: compounds 1 and 2 (each within the scatter of the next); then compound 3.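

The two methyl-bearing compounds are not interchangeable: in this assay, moving the methyl from 2-methylphenyl to 3-methylphenyl gives a 3.0-fold higher number from compound 2 to compound 3 (0.48 log units; beyond the scatter), so a larger dose is needed for an effect. The comparison with the unsubstituted phenyl points the same way, with a 3.0-fold higher number from compound 1 to compound 3 (0.48 log units; beyond the scatter), whereas the 2-methylphenyl of compound 2 gave no change at the digits printed from compound 1 to compound 2 (within the scatter); in this small set, adding a methyl to this aryl ring is therefore not neutral at every place, and its outcome depends on where the methyl sits. No measurement available here explains why the two placements differ.

The compounds shown leave open whether the higher number belongs to the methyl specifically or would appear with any group placed as in 3-methylphenyl. An ethyl, a methoxy or a chlorine at that same place on the ring would help separate these possibilities, and would show whether the 2-methylphenyl arrangement stays level with the plain phenyl when its methyl is replaced by one of those groups.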